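The source may report more compounds than this note shows. Statements on the series, on what has been measured and on what is new or still open speak of the compounds shown alone.

Compound 1 `Cc1cc(-c2ccc(C=O)cc2)cn2c(CSCCc3ccccc3)cnc12` is one of three compounds tested in an ADME assay on HEL cells (Homo sapiens) for cytotoxicity, with a stated time of 3 days; a higher number here means that more compound is tolerated, a lower number that less compound is tolerated; there compound 1 gives 100 ug/mL. Compound 3 `Cc1cc(-n2ccnc2)cn2c(CSCCc3ccccc3)cnc12` gives 100 ug/mL, and the step of no change at the digits printed from compound 1 to compound 3 (within the scatter) stays within the scatter. For compound 2 `Cc1cc(-c2ccoc2)cn2c(CSCCc3ccccc3)cnc12` the assay reports only a limit, > 4 ug/mL. Compound 4 `Cc1cc(-n2ccc3ccccc32)cn2c(CSCCc3ccccc3)cnc12` has not yet been measured. It differs from compound 1 in one place: 1H-indol-1-yl in place of 4-formylphenyl on an aromatic carbon. The closest measured step, no change at the digits printed from compound 1 to compound 3 (within the scatter), showed no change, since there too a nitrogen-linked aromatic ring replaced the 4-formylphenyl group. The step that the limit leaves unreadable from compound 1 to compound 2 gives no readable size. That is because compound 2 sits at the limit of > 4 ug/mL in this assay, at which 1 of the 3 values shown sits. No step beyond the scatter is therefore expected, no change at the digits printed from compound 1 to compound 4 (within the scatter). Compound 4 is estimated at 100 ug/mL, with a range from 40 ug/mL to 200 ug/mL.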

Compound 4, minimum cytotoxic concentration: > 20 ug/mL
Compound 4: no number, only a limit (the forecaster's own chance of this, stated with the estimate: 40%); the middle value is on the limit's open side.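

In this assay compound 4 gives only a limit, > 20 ug/mL. None of the steps from compound 1, compound 2 or compound 3 to compound 4 can be read. The compounds shown leave open where compound 2 and compound 4 truly stand relative to compound 1 and compound 3.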